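Notes on the step from compound 3 to compound 4

This account rests on a few compounds, and the source may have more. Where it says the series, first, only, none or still open, it means among the compounds named here.

In an ADME assay on microsomes from liver (Homo sapiens) for metabolic stability, with a stated time of 10 min (on this read-out lower numbers stand for a less stable compound and higher numbers for a more stable compound), compound 1 `CC[C@]1(C(=O)O)CC[C@H](C(=O)N2CC[C@](c3ccc(C(F)(C(F)(F)F)C(F)(F)F)cc3)(S(=O)(=O)c3ccc(F)cc3)C2)CC1` gives 100% and compound 2 `O=C(O)C12CCC(C(=O)N3CC[C@](c4ccc(C(F)(C(F)(F)F)C(F)(F)F)cc4)(S(=O)(=O)c4ccc(F)cc4)C3)(CC1)CC2` gives 100%. Compound 3 `O=C(N1CC[C@](c2ccc(C(F)(C(F)(F)F)C(F)(F)F)cc2)(S(=O)(=O)c2ccc(F)cc2)C1)C12CCC(C(=O)O)(CC1)OC2` offers no starting point, as its entry reads "not determined" (no result reported). The change to compound 4 `O=C(C1CCS(=O)(=O)CC1)N1CC[C@](c2ccc(C(F)(C(F)(F)F)C(F)(F)F)cc2)(S(=O)(=O)c2ccc(F)cc2)C1` is a group of 8 heavy atoms (5 carbon, 2 oxygen, 1 sulfur; one six-membered non-aromatic ring with 1 hetero atom) in place of a group of 11 heavy atoms (8 carbon, 3 oxygen; one six-membered non-aromatic ring of carbon only, one six-membered non-aromatic ring with 1 hetero atom), on a carbonyl carbon. In words, the 1,1-dioxothian-4-yl group, with one six-membered non-aromatic ring with 1 hetero atom, takes the place of a group with two six-membered rings on a carbonyl carbon.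

Among the measured compounds shown here, the only measured step that bears on this also exchanges the group on that carbonyl carbon, and it shows no change at the digits printed from compound 1 to compound 2 (within the scatter). For the measured compounds named here, its support is limited, since no measured compound carries the 1,1-dioxothian-4-yl group and compound 3 supplies no number to step from. No shift beyond the scatter is expected relative to the level of compounds 1 and 2, though any real movement could only be downward on this read-out. For compound 4 the expected value is 90%, with an estimated range of 70% to 100%.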

Compound 4, percent of the compound remaining: 93%
The estimate for compound 4 lay 3 percentage points below the measured number, and the stated range covers the measured number.
By their numbers in this assay, from the lowest: compounds 4, 1 and 2 (each within the scatter of the next).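

In this assay, among the compounds shown here, exchanging the carboxylic acid-bearing groups of the earlier compounds for 1,1-dioxothian-4-yl on the carbonyl carbon gives a number 7 percentage points lower from compound 2 to compound 4 (within the scatter) and a number 7 percentage points lower from compound 1 to compound 4 (within the scatter) as the two readable steps. The level seen with compounds 1 and 2 therefore does not depend on a carboxylic acid in the group at this place, at least for compound 4, and a group with one six-membered ring serves as well here as the larger groups. The step from compound 3 to compound 4 cannot be read, as compound 3 has no number to start from.

As far as these compounds go, whether an amine or an open alkyl chain on this carbonyl carbon would stay at the same level remains open. Nothing measured here accounts for the result.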